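Swapping a hydroxy-isopropyl for a carbamoyl group

A few compounds are considered here, and "the series" means these few. Any claim that something is new, unique, unknown or untested is made for them only; others in the source may bear on it.

Compound 1, with the structure `COc1cc(OCc2csc(-c3ccc(C(C)(C)O)cc3)n2)c2cc(-c3cn4nc(OC)sc4n3)oc2c1`, has been tested in an ADME assay on microsomes from liver (Rattus norvegicus) for metabolic stability (on this read-out lower numbers stand for a shorter-lived compound and higher numbers for a longer-lived compound), where compound 1 gives 1.15 h. Among the three measured compounds this is the second highest number. Its nearest neighbour is compound 2, `COc1cc(OCc2cccc(-c3ccc(C#N)cc3)c2)c2cc(-c3cn4nc(OC)sc4n3)oc2c1`, which in this assay gives 1.67 h, a gap that lies within the usual scatter. Furthest away is compound 3, `COc1cc(OCc2cccc(-c3cncnc3)c2)c2cc(-c3cn4nc(OC)sc4n3)oc2c1`, which in this assay gives 0.117 h, well beyond the scatter. Going by the values given here, the only single-point step among the measured compounds is a 14-fold lower number from compound 2 to compound 3 (1.15 log units; beyond the scatter), and it concerns a change on a different part of the molecule.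

Compound 4, `COc1cc(OCc2csc(-c3ccc(C(N)=O)cc3)n2)c2cc(-c3cn4nc(OC)sc4n3)oc2c1`, differs from compound 1 in one place: carbamoyl in place of 1-hydroxy-1-methylethyl on an aromatic carbon. Both the group that leaves and the group that enters carry one hydrogen-bond donor and one hydrogen-bond acceptor. Among the compounds with values here, no measured step touches this position or this pair of groups, so there is nothing in the data that points to a change in one direction or the other. The expectation for this assay is therefore that the step of a 1.2-fold lower number from compound 1 to compound 4 (0.06 log units; within the scatter) is estimated to stay within the scatter, with wide uncertainty. Compound 4 is expected to give about 1 h, in a range from 0.35 h to 2.8 h.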

Compound 4, half-life: 0.4 h
For compound 4 the middle estimate is 2.5-fold (0.40 log units) above the measured one, within the range that was stated.
By their numbers in this assay, from the lowest: compound 3; then compound 4; then compounds 1 and 2 (each within the scatter of the next).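

In this assay, the change from 1-hydroxy-1-methylethyl to carbamoyl gives a 2.9-fold lower number from compound 1 to compound 4 (0.46 log units; beyond the scatter), the first measured sign that the number responds to what sits at this place, on an aromatic carbon of a six-membered aromatic ring of carbon only. The two groups count the same hydrogen-bond donors and acceptors, so matching those counts was not enough to hold the half-life level in this pair; they do differ in their heavy atoms, and carbamoyl carries a double bond outside aromatic rings. Nothing in the available data says why the number moves.

From the compounds shown here alone, with only these two groups seen at this place, it stays open whether the lower number is particular to carbamoyl or would also appear with a carboxylic acid, an amine or a longer chain ending in a hydroxy group. Going by these compounds, it is also open whether the same exchange would shift the number in the same direction on the 4-cyanophenyl side chain of compound 2, where the rest of the molecule differs from compound 1.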